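The source may report more compounds than this note shows. Statements on the series, on what has been measured and on what is new or still open speak of the compounds shown alone.

Measured compounds:
compound 1 `Cc1ccccc1NC(=O)N[C@H](C)c1ccccc1` gives 100% in an ADME assay on the whole organism with Oryza sativa as the target, tested at 0.1 uM; on this read-out lower numbers stand for a stronger effect and higher numbers for a weaker effect at the one concentration tested
compound 2 `CCCCc1ccc(NC(=O)N[C@H](C)c2ccccc2)cc1` gives 100% in this assay
compound 3 `CCCCc1ccc(NC(=O)N[C@@H](C)c2ccccc2)cc1` gives 98% in this assay

All three compounds share one core and give numbers that sit close together. Compound 3 stands with compound 1 and compound 2 within the usual scatter of this read-out, so none of the three can be set apart from the others. Among the compounds with values here, the only measured single change is a number 2 percentage points lower from compound 2 to compound 3 (within the scatter), and it rests on (the fact that compounds 2 and 3 differ only in the configuration as drawn); it tells nothing about swapping one group for another on the aromatic ring.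

Compound 4 `CCOC(=O)c1ccc(NC(=O)N[C@@H](C)c2ccccc2)cc1` is not yet measured. It differs from compound 3 in one place: ethoxycarbonyl in place of butyl on an aromatic carbon. Within the data shown here, no measured step among the three compounds involves a change of this kind, so there is no direct guide to its size or direction. Since every measured compound gives a number near the top of the scale, the expected step of a number 3 percentage points lower from compound 3 to compound 4 (within the scatter) is no change beyond the scatter, with some room for a weaker effect. Compound 4 is therefore estimated at 95%, in a range from 75% to 100%.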

Compound 4, a percentage reported as activity, at one concentration (the size of the read-out at that concentration, not a potency): 99%
For compound 4 the middle estimate is 4 percentage points below the measured one; low and high end bracket the measured number.
By their numbers in this assay, from the lowest: compounds 3, 4, 1 and 2 (each within the scatter of the next).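

In this assay, putting ethoxycarbonyl in place of butyl on this aromatic carbon, para to a large group, gives a number 1 percentage points higher from compound 3 to compound 4 (within the scatter). Within the data shown here, this is the first measured step that changes a group rather than the drawn configuration, and it shows that an oxygen-bearing ester group and an all-carbon chain cannot be told apart at this position at the one concentration tested. Nothing measured here explains why the read-out stays where it is.

The compounds shown leave open whether an amine, a carboxylic acid or a longer chain at this position would move the number beyond the scatter. They also leave open whether ethoxycarbonyl would give a similar number with the stereocentre drawn the opposite way, as it is in compound 2.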